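The source may report more compounds than this note shows. Statements on the series, on what has been measured and on what is new or still open speak of the compounds shown alone.

Working notes on the series, read in a physicochemical assay for lipophilicity; on this read-out lower numbers stand for lower lipophilicity and higher numbers for higher lipophilicity. Compound 1 (`C=C(c1cccc2ccccc12)C1CCC2(CC1)COC(Nc1ccccc1)OO2`) gives 5.59. Compound 2 (`C=C(c1cccc2ccccc12)C1CCC2(CC1)COC(Nc1ccc(F)cc1)OO2`) gives 5.75. Compound 3 (`C=C(c1cccc2ccccc12)C1CCC2(CC1)COC(Nc1ccc(Cl)cc1)OO2`) gives 6.15, the highest of the three numbers, and it stands clear of both others: a number 0.40 log units higher from compound 2 to compound 3 (beyond the scatter) and a number 0.56 log units higher from compound 1 to compound 3 (beyond the scatter).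

Compound 4 (`C=C(c1cccc2ccccc12)C1CCC2(CC1)COC(Nc1cc(Cl)cc(Cl)c1)OO2`) carries 3,5-dichlorophenyl in place of 4-chlorophenyl on an amine nitrogen. The closest measured step is chloro in place of hydrogen on an aromatic carbon, a number 0.56 log units higher from compound 1 to compound 3 (beyond the scatter), which is modest and beyond the scatter. Fluoro in place of hydrogen, a number 0.16 log units higher from compound 1 to compound 2 (within the scatter), stays within the scatter and offers little guidance here. Going by the values given here, no measured compound carries 3,5-dichlorophenyl, so whether chloro steps add up remains untested.

Going by the chloro step a number 0.56 log units higher from compound 1 to compound 3 (beyond the scatter), a modest upward move of similar size is expected in this assay, and the estimated step is a number 0.55 log units higher from compound 3 to compound 4 (beyond the scatter). The estimate for compound 4 is 6.7, with an expected range of 6.3 to 7.1.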

Compound 4, partition coefficient: 6.71
Compound 4: the middle estimate sits 0.01 log units below what was measured; low and high end bracket the measured number.
By their numbers in this assay, from the lowest: compounds 1 and 2 (each within the scatter of the next); then compound 3; then compound 4.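

In this assay, 3,5-dichlorophenyl on the amine nitrogen extends the rise seen with a single chloro: a number 0.56 log units higher from compound 3 to compound 4 (beyond the scatter), a step of the same printed size as a number 0.56 log units higher from compound 1 to compound 3 (beyond the scatter). Among the chloro compounds, the number therefore climbs with each added chloro, and the full span, a number 1.12 log units higher from compound 1 to compound 4 (beyond the scatter), is the only large step in the series. Fluoro does not fit this picture as closely, since a number 0.16 log units higher from compound 1 to compound 2 (within the scatter) stays within the scatter, whereas a number 0.96 log units higher from compound 2 to compound 4 (beyond the scatter) lies beyond it.

Still open, from the compounds shown here alone, is whether the rise follows the count of chloro groups or their placement, as this step alters both, and how a ring bearing an amine or a carboxylic acid would read. No supporting measurement speaks to what lies behind these steps.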